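This account rests on a few compounds, and the source may have more. Where it says the series, first, only, none or still open, it means among the compounds named here.

In a functional assay on T-24 cells (Homo sapiens) for cytotoxicity, read by neutral red uptake, with a stated time of 72 h (a lower number here means a stronger inhibitor, a higher number a weaker inhibitor), compound 2 `CCNc1nc(SCC)nc2ncccc12` gives 20100 nM, the higher of the two numbers recorded so far. Going by the values given here, the only other compound measured, compound 1 `COc1ccc(CNc2nc(NCc3ccc(OC)cc3)c3ccccc3n2)cc1`, gives 3870 nM in this assay, a lower number by a gap that lies beyond the usual scatter; the two structures differ in many places at once, so no single step joins them, and only the two values themselves can be compared. Compound 3 `CCCCCNc1nc(SCC)nc2ncccc12` is compound 2 with propyl in place of hydrogen on a saturated chain carbon, two bonds along the chain from a nitrogen on an aromatic ring. Among the compounds with values here, no measured pair traces this change, so the expectation rests on the nature of the change alone. A small step is expected, if any, most likely toward a lower number, and it may well remain within the scatter. Compound 3 is therefore estimated at 12000 nM, with a range from 4000 nM to 35000 nM. The step expected in this assay is a 1.7-fold lower number from compound 2 to compound 3 (0.22 log units; within the scatter).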

Compound 3, half-maximal inhibitory concentration: 4300 nM
Compound 3: middle estimate off by 2.8-fold (0.45 log units), on the high side, and the stated range covers the measured number.
By their numbers in this assay, from the lowest: compounds 1 and 3 (each within the scatter of the next); then compound 2.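

Going by these compounds alone, the change from ethylamino to pentylamino gives, in this assay, a 4.7-fold lower number from compound 2 to compound 3 (0.67 log units; beyond the scatter), the only step in this set that can be read at a single place. It shows that this saturated chain carbon, two bonds along the chain from a nitrogen on an aromatic ring, does not merely tolerate propyl in place of hydrogen: the added carbon chain, which brings no ring, no hydrogen-bond donor or acceptor and no net charge, goes with a lower number. Nothing in the available data accounts for the size of this step.

Going by these compounds, since this is one step at one chain length, it remains open whether a longer chain such as octyl would lower the number further or reverse the change. On these data alone, it is equally open how a terminal amine, a carboxylic acid or a cyclohexyl ring on the same chain would read.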